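From ethyl to 4-methylphenyl on the aromatic nitrogen

A few compounds are considered here, and "the series" means these few. Any claim that something is new, unique, unknown or untested is made for them only; others in the source may bear on it.

Compound 1 (`CCn1ccnc1-c1cc(OC)c(OC)c(OC)c1`) gives > 100000 nM in a functional assay on HCT-15 cells (Homo sapiens) for antiproliferative activity, read by MTT assay, with a stated time of 72 h (on this read-out lower numbers stand for stronger inhibition and higher numbers for weaker inhibition), and this is a limit of the assay, not a number. Compound 1 therefore stands at the limit of > 100000 nM in this assay, at which 2 of the 3 values shown sit. Compound 2 (`CCCn1ccnc1-c1cc(OC)c(OC)c(OC)c1`), the next chain length, gives > 100000 nM, which is also a limit. Among the compounds with values here, compound 3 (`COc1cc(-c2nccn2-c2ccc3[nH]ccc3c2)cc(OC)c1OC`), with an aromatic group on the same nitrogen, gives 4600 nM in this assay, the only true number so far.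

Compound 4 (`COc1cc(-c2nccn2-c2ccc(C)cc2)cc(OC)c1OC`) keeps the shared core and carries 4-methylphenyl in place of ethyl on an aromatic nitrogen. Within the data shown here, the only measured step is a step that the two limits leave unreadable from compound 1 to compound 2, so it offers no size to carry over. The expectation rests instead on compound 3 and its value of 4600 nM, since an aromatic group sits there as it would in compound 4. The two aromatic groups differ, so the range stays wide, and a limit reading remains possible. The expected change is towards stronger inhibition, with an estimated size of an at least 16-fold lower number from compound 1 to compound 4 (1.22 log units; beyond the scatter). Compound 4 is expected at about 6000 nM, with an estimated range of 800 nM to 45000 nM.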

Compound 4, half-maximal inhibitory concentration: 800 nM
For compound 4 the middle estimate is 7.5-fold (0.88 log units) above the measured one; measured number inside the range.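

Replacing ethyl with 4-methylphenyl on the aromatic nitrogen gives an at least 120-fold lower number from compound 1 to compound 4 (2.09 log units; beyond the scatter) in this assay, and replacing propyl with the same group gives an at least 120-fold lower number from compound 2 to compound 4 (2.09 log units; beyond the scatter). Both steps start from a limit of the assay, not a number: the limit of > 100000 nM in this assay, at which 2 of the 4 values shown sit. Compound 3 at 4600 nM and compound 4 at 800 nM both carry an aromatic group on this nitrogen and both give true numbers, so among the four compounds shown a readable value appears only with such a group, and no compound goes against this.

As far as these compounds go, it remains open whether the aromatic ring itself matters or only the larger group, a question that cyclohexyl or benzyl on the same nitrogen would address. Also open, from the compounds shown here alone, is what the methyl of compound 4 contributes, which plain phenyl, 4-methoxyphenyl or 4-chlorophenyl in the same place would help to separate from the effect of the ring.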